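This account rests on a few compounds, and the source may have more. Where it says the series, first, only, none or still open, it means among the compounds named here.

Of the compounds shown here, three have been tested in a functional assay on MDA-MB-231 cells (Homo sapiens) for inhibition, read by MTT assay, with a stated time of 72 h, tested at 20 uM; on this read-out lower numbers stand for less inhibition and higher numbers for more inhibition at the one concentration tested (going by the name of the read-out). Compound 1 `CN(c1ccc(Oc2ncnc3ccsc23)cc1)c1nccc(N2CCc3ccccc3C2)n1` gives 30.2% in this assay. Compound 2 `CN(c1ccc(Oc2ncnc3ccsc23)cc1)c1nccc(N2CCc3ccccc32)n1` differs from compound 1 in one place, (2,3-dihydro-1H-indol-1-yl in place of 1,2,3,4-tetrahydroisoquinolin-2-yl on an aromatic carbon); in this assay compound 2 gives 38.2%, a step of a number 8 percentage points higher from compound 1 to compound 2 (within the scatter). Compound 3 `c1ccc2c(c1)CCN(c1ccnc(Nc3ccc(Oc4ncnc5sccc45)cc3)n1)C2` is built on another core, and the difference between the two cores is not broken down here. In this assay compound 3 gives 26.8%; its gap to compound 1 lies within the scatter, while its gap to compound 2 lies beyond it.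

Compound 4 `c1ccc2c(c1)CCN2c1ccnc(Nc2ccc(Oc3ncnc4sccc34)cc2)n1` has not yet been measured. It arises from compound 3 by the same change that links compound 1 to compound 2, (2,3-dihydro-1H-indol-1-yl in place of 1,2,3,4-tetrahydroisoquinolin-2-yl on an aromatic carbon), at the same place on the ring. For the measured compounds named here, the only guide to its size is the earlier step of a number 8 percentage points higher from compound 1 to compound 2 (within the scatter), which stayed within the scatter. A step of about a number 6.2 percentage points higher from compound 3 to compound 4 (within the scatter) is therefore expected because the earlier step of a number 8 percentage points higher from compound 1 to compound 2 (within the scatter) was small. For compound 4 the expected value in this assay is 33%, with a likely range from 20% to 46%.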

Compound 4, a percentage reported as inhibition, at one concentration (the size of the read-out at that concentration, not a potency): 9.95%
Estimate against measurement, compound 4: 23.1 percentage points above; measured number below the stated range.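

Replacing 1,2,3,4-tetrahydroisoquinolin-2-yl with 2,3-dihydro-1H-indol-1-yl did not have the same effect on the two cores in this assay: the same change on two cores in this assay, a number 8 percentage points higher (within the scatter) from compound 1 to compound 2 and a number 16.9 percentage points lower (beyond the scatter) from compound 3 to compound 4, 24.9 percentage points apart, beyond the scatter of two such steps. On the core of compound 3 the change gives a number 16.9 percentage points lower from compound 3 to compound 4 (beyond the scatter), so in these four compounds the step seen on one core was a poor guide to the step on the other. For the compounds shown here, this rests on only one pair of compounds per core at a single concentration, so it shows that the effect of this change depends on the core here, but not which part of the core is responsible or why, and it sets no rule for other cores.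

On these data alone, it remains open which of the differences between the two cores matters. As far as these compounds go, it is also open how an open-chain amine such as dimethylamino, or a morpholin-4-yl ring, would behave at this same place on each core.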